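A Second Fluoro on the Aryl Group: Compound 4

A few compounds are considered here, and "the series" means these few. Any claim that something is new, unique, unknown or untested is made for them only; others in the source may bear on it.

The three measured compounds and their values:
Compound 1, `Cc1cc(=O)n(-c2ccc(F)c(F)c2)nc1C(=O)Nc1ccc(Oc2ncnc3ccsc23)cc1`, gives 8180 nM.
Compound 2, `Cc1cc(=O)n(-c2ccccc2C(F)(F)F)nc1C(=O)Nc1ccc(Oc2ncnc3ccsc23)c(F)c1`, gives 4680 nM.
Compound 3, `Cc1cc(=O)n(-c2cccc(F)c2)nc1C(=O)Nc1ccc(Oc2ncnc3ccsc23)c(F)c1`, gives 5220 nM.

All three were tested in a functional assay on A549 cells (Homo sapiens) for cytotoxicity, read by MTT assay, with a stated time of 72 h; on this read-out higher numbers stand for weaker inhibition and lower numbers for stronger inhibition. Among the measured compounds shown here, compound 3 stands second highest of the three numbers; the single measured step on record is a 1.1-fold higher number from compound 2 to compound 3 (0.05 log units; within the scatter), so compound 2 and compound 3 cannot be told apart by this measurement. Compound 1, which carries the 3,4-difluorophenyl but lacks the fluoro on the other aromatic ring, gives a number only modestly higher than compound 3, and the two are within the scatter of each other.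

Compound 4, `Cc1cc(=O)n(-c2ccc(F)c(F)c2)nc1C(=O)Nc1ccc(Oc2ncnc3ccsc23)c(F)c1`, differs from compound 3 by fluoro in place of hydrogen on an aromatic carbon, the new fluoro sitting ortho to the existing fluoro group and para to a large group; in other words, 3-fluorophenyl becomes 3,4-difluorophenyl. For the measured compounds named here, no measured step follows exactly this change, and the one step recorded concerns a different position. Since compound 1 already carries this group and sits close to compound 3, the step of a 1.1-fold higher number from compound 3 to compound 4 (0.06 log units; within the scatter) is expected to stay within the scatter. Compound 4 is therefore estimated at 6000 nM, within 3000 nM to 12000 nM.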

Compound 4, half-maximal inhibitory concentration: 4590 nM
Compound 4: the middle estimate sits 1.3-fold (0.12 log units) above what was measured; the measured number falls inside the stated range.
By their numbers in this assay, from the lowest: compounds 4, 2, 3 and 1 (each within the scatter of the next).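

In this assay, turning 3-fluorophenyl into 3,4-difluorophenyl adds one fluoro atom, and the result is a 1.1-fold lower number from compound 3 to compound 4 (0.06 log units; within the scatter), so this position accepts the extra fluoro without a readable change in the number. Swapping the whole aryl group gives the same picture, with a 1.0-fold lower number from compound 2 to compound 4 (0.01 log units; within the scatter), which means that 3,4-difluorophenyl and 2-(trifluoromethyl)phenyl cannot be told apart here, and the fluoro on the other aromatic ring, now tested with 3,4-difluorophenyl in place, gives a 1.8-fold lower number from compound 1 to compound 4 (0.25 log units; within the scatter), so neither fluoro shows a separate effect in this set. No outside measurement helps to interpret how closely these numbers agree.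

The aryl groups shown carry only fluoro and trifluoromethyl, so it remains open whether an amine, a carboxylic acid or a methoxy group on the same ring would leave the number unchanged or move it beyond the scatter. Since all the steps here stay within the scatter, these compounds also leave open which part of the structure, if any, controls the number in this assay, and a change to the shared core might answer that.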